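Trifluoromethoxy in place of trifluoromethyl on compound 2

A few compounds are considered here, and "the series" means these few. Any claim that something is new, unique, unknown or untested is made for them only; others in the source may bear on it.

In a functional assay on VCaP cells (Homo sapiens) for antiproliferative activity, read by propidium iodide staining, with a stated time of 96 h (on this read-out lower numbers stand for stronger inhibition and higher numbers for weaker inhibition), compound 2 `CC(O)(CSc1cccc(C(F)(F)F)c1)C(=O)Nc1ccc(S(F)(F)(F)(F)F)cc1` gives 18800 nM. Compound 1 `CC(O)(CSc1cccc(S(F)(F)(F)(F)F)c1)C(=O)Nc1ccc(S(F)(F)(F)(F)F)cc1` gives 28200 nM, and compound 3 `CC(O)(CSc1ccccc1C(F)(F)F)C(=O)Nc1ccc(S(F)(F)(F)(F)F)cc1` gives 21000 nM. Compound 2 therefore sits within the scatter of both other compounds. The next change leads to compound 4 `CC(O)(CSc1cccc(OC(F)(F)F)c1)C(=O)Nc1ccc(S(F)(F)(F)(F)F)cc1`: trifluoromethoxy in place of trifluoromethyl on an aromatic carbon, with trifluoromethoxy in place of trifluoromethyl on an aromatic carbon. For the measured compounds named here, two measured steps bear on it. Exchanging the group gave a 1.5-fold lower number from compound 1 to compound 2 (0.18 log units; within the scatter), and shifting the trifluoromethyl gave a 1.1-fold higher number from compound 2 to compound 3 (0.05 log units; within the scatter), both within the scatter. The expected step is a 1.1-fold higher number from compound 2 to compound 4 (0.03 log units; within the scatter), so no change beyond the scatter is expected in this assay. For compound 4 the estimated value is 20000 nM, with an expected range of 11000 nM to 36000 nM.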

Compound 4, half-maximal inhibitory concentration: 13800 nM
Beside the measured number, compound 4's estimate is 1.4-fold (0.16 log units) above it, within the range that was stated.
By their numbers in this assay, from the lowest: compounds 4, 2, 3 and 1 (each within the scatter of the next, the first and the last beyond it).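

In this assay, the step of a 1.4-fold lower number from compound 2 to compound 4 (0.13 log units; within the scatter) keeps trifluoromethoxy within the scatter of trifluoromethyl at this position, meta to a large group. For the compounds shown here, the step of a 2.0-fold lower number from compound 1 to compound 4 (0.31 log units; beyond the scatter) is the first beyond the scatter, though it is modest and comes from exchanging the group of 6 heavy atoms for trifluoromethoxy. No evidence on hand explains either step. On these data alone, whether an amine or a carboxylic acid at this position would shift the number beyond the scatter of trifluoromethoxy remains open.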